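Lengthening the chain on the aromatic nitrogen

The source may report more compounds than this note shows. Statements on the series, on what has been measured and on what is new or still open speak of the compounds shown alone.

The series shares one core, carried by compound 1 `Cc1nn(C)c2c1C(c1ccccc1Cl)=NCC(=O)N2`, compound 2 `CCn1nc(C)c2c1NC(=O)CN=C2c1ccccc1Cl`, compound 3 `C=CCN1C(=O)CN=C(c2ccccc2Cl)c2c(C)nn(CC)c21` and the still unmeasured compound 4 `CCCn1nc(C)c2c1NC(=O)CN=C2c1ccccc1Cl`. In a functional assay on the whole organism (strain Holtzman) with Rattus norvegicus as the target (on this read-out higher numbers stand for an effect only at larger amounts of compound and lower numbers for an effect already at smaller amounts), compound 1 gives 2.5 mg/kg and compound 2 gives 5 mg/kg; of the two numbers compound 2 stands highest, with a 2.0-fold higher number from compound 1 to compound 2 (0.30 log units; within the scatter). For compound 3 the assay reports only a limit, > 40 mg/kg. Compound 3 differs from compound 2 by allyl in place of hydrogen on an amide-type nitrogen in a ring, and that step read an at least 8.0-fold higher number from compound 2 to compound 3 (0.90 log units; beyond the scatter).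

Compound 4 differs from compound 2 by methyl in place of hydrogen on a saturated chain carbon, two bonds along the chain from an aromatic nitrogen. The step that bears most closely on it is the one on the same chain, from compound 1 to compound 2, which gave a 2.0-fold higher number from compound 1 to compound 2 (0.30 log units; within the scatter). The step from compound 2 to compound 3 concerns the amide-type nitrogen in the ring and speaks less to this change. The expectation is therefore no step beyond the scatter in this assay, at most a mild drift to higher numbers, a 1.4-fold higher number from compound 2 to compound 4 (0.15 log units; within the scatter). For compound 4 the estimate is 7 mg/kg, within a range from 2.5 mg/kg to 20 mg/kg.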

Compound 4, minimum effective dose: 40 mg/kg
Estimate against measurement, compound 4: 5.7-fold (0.76 log units) below, and the stated range ends below it.
By their numbers in this assay, from the lowest: compounds 1 and 2 (each within the scatter of the next); then compound 4.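

Going from ethyl to propyl on the aromatic nitrogen turns out to matter in this assay: it gives an 8.0-fold higher number from compound 2 to compound 4 (0.90 log units; beyond the scatter), whereas methyl to ethyl had given only a 2.0-fold higher number from compound 1 to compound 2 (0.30 log units; within the scatter). Read over the whole chain, the change from methyl to propyl amounts to a 16-fold higher number from compound 1 to compound 4 (1.20 log units; beyond the scatter). This position therefore does respond to chain length, and among the three chains shown, the response beyond the scatter appears only with propyl.

As far as these compounds go, whether a butyl chain, a branched isopropyl group or a chain ending in a hydroxyl or an amine would follow propyl remains open. Compound 3 adds no number to this picture, as it is reported only as a limit: the limit of > 40 mg/kg in this assay, at which 1 of the 4 values shown sits.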